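This account rests on a few compounds, and the source may have more. Where it says the series, first, only, none or still open, it means among the compounds named here.

Three compounds share one core. Compound 1 `CC(C)[C@H](NC(=O)[C@]1(Cc2ccccc2)CCN1C(=O)OCc1ccccc1)C(N)=O` carries a 1-carbamoyl-2-methylpropyl group on an amide-type nitrogen; in an ADME assay on HELF cells (Homo sapiens) for cytotoxicity, with a stated time of 3 days (a higher number here means that more compound is tolerated, a lower number that less compound is tolerated), compound 1 gives 100000 nM. Compound 2 `C[C@H](NC(=O)[C@]1(Cc2ccccc2)CCN1C(=O)OCc1ccccc1)C(=O)NC1CCCCC1` carries a 1-(cyclohexylcarbamoyl)ethyl group in that place. For compound 2 the result in this assay is a limit of the assay, > 100000 nM. Compound 3 `C[C@H](NC(=O)[C@]1(Cc2ccccc2)CCN1C(=O)OCc1ccccc1)C(=O)NCc1ccccc1` carries a 1-(benzylcarbamoyl)ethyl group, and in this assay compound 3 gives 42000 nM. Among the two plain numbers compound 3 stands lowest: its nearest neighbour is compound 1, with a 2.4-fold lower number from compound 1 to compound 3 (0.38 log units; beyond the scatter), while the remaining value sits at the limit of > 100000 nM in this assay, at which 1 of the 3 values shown sits.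

Compound 4 `C[C@H](NC(=O)[C@]1(Cc2ccccc2)CCN1C(=O)OCc1ccccc1)C(=O)N(C)C` differs from compound 3 in one place: dimethylamino in place of benzylamino on a carbonyl carbon. Among the measured compounds shown here, two measured steps bear on this change. Putting benzyl in place of cyclohexyl gave an at least 2.3-fold lower number from compound 2 to compound 3 (0.37 log units; beyond the scatter), and moving from compound 1 to the benzyl-bearing compound 3 gave a 2.4-fold lower number from compound 1 to compound 3 (0.38 log units; beyond the scatter); in both cases the benzyl-bearing compound showed the lower number. Taking the benzyl group away again is therefore expected to move the number back upward, by a modest amount, with a 2.1-fold higher number from compound 3 to compound 4 (0.33 log units; beyond the scatter) as the expected step. For compound 4 the expected value is 90000 nM, within a range from 40000 nM to 200000 nM.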

Compound 4, half-maximal cytotoxic concentration: > 100000 nM
Compound 4: no number, only a limit (the forecaster's own chance of this, stated with the estimate: 45%); middle value at least 1.1-fold (0.04 log units) from the limit.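

In this assay, the step from benzylamino to dimethylamino on this carbonyl carbon gives an at least 2.3-fold higher number from compound 3 to compound 4 (0.37 log units; beyond the scatter), so the lower number of compound 3 does not carry over to a small group without a ring. Compound 4 gives a limit of the assay rather than a number, the same kind of result as compound 2: the limit of > 100000 nM in this assay, at which 2 of the 4 values shown sit. Among compound 2, compound 3 and compound 4, which differ only in the group on this carbonyl carbon, only benzylamino, the one group of the three with an aromatic ring, gives a plain number, and with a single such compound this is an observation and not yet a rule.

Going from the other side gives only a direction, a number no lower from compound 1 to compound 4 (the limit leaves the size open), and the step between compound 2 and compound 4 cannot be read at all, so how these compounds rank at the top of the range stays unknown. Going by these compounds, it also stays open whether the lower number follows the aromatic ring itself, which a phenylamino, a 2-phenylethylamino or a pyridylmethylamino group on the same carbonyl carbon would help to separate.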